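A few compounds are considered here, and "the series" means these few. Any claim that something is new, unique, unknown or untested is made for them only; others in the source may bear on it.

Measured so far in a functional assay on OE19 cells (Homo sapiens) for cytotoxicity, read by MTT assay, with a stated time of 48 h; a lower number here means a stronger inhibitor, a higher number a weaker inhibitor:
- compound 1 `CCOC(=O)/C=C1/C(=O)N2[C@@H]1SC(C)(C)[C@@H]2C(=O)OC(c1ccccc1)c1ccccc1`: 11200 nM
- compound 2 `CC1(C)S[C@@H]2/C(=C\C(=O)OCc3ccccc3)C(=O)N2[C@H]1C(=O)OC(c1ccccc1)c1ccccc1`: 8200 nM

For the measured compounds named here, compound 2 holds the lowest of the two numbers in this assay; its only neighbour is compound 1, and the gap between them, a 1.4-fold lower number from compound 1 to compound 2 (0.14 log units; within the scatter), lies within the scatter, so the two are not separated.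

Compound 3 `COC(=O)/C=C1/C(=O)N2[C@@H]1SC(C)(C)[C@@H]2C(=O)OC(c1ccccc1)c1ccccc1` is not yet measured in this assay. It differs from compound 2 by hydrogen in place of phenyl on a saturated chain carbon bound to an oxygen next to a carbonyl group. Going by the values given here, the one measured step at this place, a 1.4-fold lower number from compound 1 to compound 2 (0.14 log units; within the scatter), is the reverse kind of change (phenyl put onto the chain carbon) and produced no shift beyond the scatter. Removing the phenyl again is therefore expected to leave the number roughly where compound 2 stands, because a 1.4-fold lower number from compound 1 to compound 2 (0.14 log units; within the scatter) gave no movement that could be reversed; the expected step is a 1.2-fold higher number from compound 2 to compound 3 (0.09 log units; within the scatter).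

Compound 3 is estimated at 10000 nM in this assay, with a range from 4000 nM to 25000 nM.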

Compound 3, half-maximal inhibitory concentration: 20200 nM
For compound 3 the middle estimate is 2.0-fold (0.31 log units) below the measured one; low and high end bracket the measured number.
By their numbers in this assay, from the lowest: compounds 2, 1 and 3 (each within the scatter of the next, the first and the last beyond it).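

In this assay the change from benzyloxycarbonyl to methoxycarbonyl gives a 2.5-fold higher number from compound 2 to compound 3 (0.39 log units; beyond the scatter) and so shows that this place on the saturated chain carbon can move the number, which the first pair alone did not show. Hydrogen in place of methyl gives a 1.8-fold higher number from compound 1 to compound 3 (0.26 log units; within the scatter) and stays within the scatter, so only compound 2 and compound 3 are separated, while compound 1 is separated from neither. No measured evidence bears on the origin of this modest step.

On these data alone, whether this place tolerates a longer chain, or a free carboxylic acid or an amide in place of the ester, remains open. As far as these compounds go, all three numbers also come from a single cell line, so it is unknown whether the step between compound 2 and compound 3 holds in other cells.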